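A Naphthalenyl Swap in a Cytotoxicity Series

The compounds below may be only part of what the source reports. "The series", "measured", "known", "first", "only" and "open" are said of these compounds alone.

Two compounds sharing one core have been examined in a functional assay on Ehrlich cells (Mus musculus) for cytotoxicity, tested at 100 ug/mL; a higher number here means a stronger effect of the compound at the concentration tested, a lower number a weaker effect. Compound 1 `COc1cc(N2C(N)=C(C#N)C(c3ccc([N+](=O)[O-])cc3)C3=C2CC(C)(C)CC3=O)cc(OC)c1OC` bears a 4-nitrophenyl group on a saturated ring carbon; in this assay compound 1 gives 80%. Compound 2 `COc1cc(N2C(N)=C(C#N)C(c3ccc(OC)c4ccccc34)C3=C2CC(C)(C)CC3=O)cc(OC)c1OC` carries a 4-methoxynaphthalen-1-yl group on that carbon instead, and in this assay compound 2 gives 40%. That single exchange brought a number 40 percentage points lower from compound 1 to compound 2 (beyond the scatter), so compound 2 stands as the lower of the two numbers, with compound 1 above it by a margin beyond the scatter.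

Compound 3 `COc1cc(N2C(N)=C(C#N)C(c3c(O)ccc4ccccc34)C3=C2CC(C)(C)CC3=O)cc(OC)c1OC` has not yet been tested. It differs from compound 2 in one place: 2-hydroxynaphthalen-1-yl in place of 4-methoxynaphthalen-1-yl on a saturated ring carbon. Within the data shown here, the only measured step, the one from compound 1 to compound 2, replaced a nitrophenyl group by a naphthalenyl group and cannot tell how a change from a methoxy-bearing to a hydroxyl-bearing naphthalenyl group will act. Nothing in the two numbers therefore points to a shift beyond the scatter. Compound 3 is accordingly expected to give about 40% in this assay, between 20% and 65%. This amounts to an expected step of no change at the digits printed from compound 2 to compound 3 (within the scatter).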

Compound 3, a percentage reported as activity, at one concentration (the size of the read-out at that concentration, not a potency): 90%
Beside the measured number, compound 3's estimate is 50 percentage points below it; the whole stated range lies below it.
By their numbers in this assay, from the lowest: compound 2; then compounds 1 and 3 (each within the scatter of the next).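

The result shows that the group on this saturated ring carbon is not settled by the naphthalenyl skeleton alone: 4-methoxynaphthalen-1-yl and 2-hydroxynaphthalen-1-yl each carry 2 six-membered aromatic rings of carbon only, yet exchanging the first for the second gave a number 50 percentage points higher from compound 2 to compound 3 (beyond the scatter) in this assay. The earlier fall on leaving 4-nitrophenyl therefore does not hold for every naphthalenyl group, as the direct exchange of 4-nitrophenyl for 2-hydroxynaphthalen-1-yl gives a number 10 percentage points higher from compound 1 to compound 3 (within the scatter). Nothing available on these compounds accounts for the large step between the two naphthalenyl groups.

This exchange alters two things at once, the methoxy group becoming a hydroxyl and the oxygen-bearing group changing its place on the naphthalene, so the three compounds cannot say which of the two goes with the higher number. A 2-methoxynaphthalen-1-yl or 4-hydroxynaphthalen-1-yl group would separate these two changes, and a 2-aminonaphthalen-1-yl group would show whether an amine at that place on the naphthalene behaves as the hydroxyl does.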